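Cytotoxicity notes: the single enantiomer of compound 3

The source may hold more compounds than are shown below. What is called first, only, known or untested is meant among the compounds shown, and "the series" means these compounds.

Compound 1 `COCOc1ccc(CN(Cc2ccc(C(C)(C)C)cc2)Cc2cc3cc(C)ccc3[nH]c2=O)cc1` gives 6400 nM in a toxicity assay on MDCK cells (Canis lupus familiaris) for cytotoxicity, read by crystal violet staining, with a stated time of 48 h; on this read-out higher numbers stand for lower toxicity in this test and lower numbers for higher toxicity in this test.
Compound 2 `Cc1ccc2[nH]c(=O)c(CN(Cc3ccc(SC(F)F)cc3)Cc3ccc(C(C)(C)C)cc3)cc2c1` gives only a limit, > 5000 nM, in this assay.
Compound 3 `Cc1ccc2[nH]c(=O)c(CN(Cc3ccc(C(C)(C)C)cc3)C(C)c3ccc(F)cc3)cc2c1` gives only a limit, > 33000 nM, in this assay.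

Compound 3 thus stands at the limit of > 33000 nM in this assay, at which 1 of the 3 values shown sits, the least toxic reading shown here. The readable step is an at least 5.1-fold higher number from compound 1 to compound 3 (0.71 log units; beyond the scatter); the steps a step that the limit leaves unreadable from compound 1 to compound 2 and a step that the two limits leave unreadable from compound 2 to compound 3 cannot be sized because of the limit of > 5000 nM in this assay, at which 1 of the 3 values shown sits, and (the limit of > 33000 nM in this assay, at which 1 of the 3 values shown sits).

Compound 4 `Cc1ccc2[nH]c(=O)c(CN(Cc3ccc(C(C)(C)C)cc3)[C@H](C)c3ccc(F)cc3)cc2c1` differs from compound 3 only in that (the two compounds have the same atoms and bonds; at least one stereo element is drawn with a configuration in one of them and without one in the other: 1 of 1 stereo elements differ; a stereocentre at a saturated chain carbon is drawn without a configuration in compound 3 and R in compound 4). Among the compounds with values here, no measured step in this set separates an enantiomer from its racemate, so the expected step is a step that the limit leaves unreadable from compound 3 to compound 4, none beyond the scatter. For compound 4 the expected value in this assay is 40000 nM, with a range of 17000 nM to 100000 nM, most likely again reported as a limit.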

Compound 4, half-maximal cytotoxic concentration: > 5000 nM
Compound 4: a limit, no number; the forecaster's own chance of this, stated with the estimate: 75%; the middle value does not contradict the limit.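

Within the data shown here, compound 4 gives only a limit, > 5000 nM, in this assay, so no new step from compound 1, compound 2 or compound 3 can be read. The compounds shown leave open whether compound 4, drawn R, truly differs from compound 3, drawn without a configuration, in this assay.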